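Aryl sulfonate series: propyl analogue with methoxyphenyl ester

The source may hold more compounds than are shown below. What is called first, only, known or untested is meant among the compounds shown, and "the series" means these compounds.

Compound 3 `CCCN1CCN(c2ccc(S(=O)(=O)Oc3ccccc3CC)cc2)C1=O` gives in a functional assay on M21 cells (Homo sapiens) for antiproliferative activity, read by sulforhodamine B assay, with a stated time of 48 h (on this read-out higher numbers stand for weaker inhibition and lower numbers for stronger inhibition), only a limit, > 50000 nM, which is the limit of > 50000 nM in this assay, at which 1 of the 3 values shown sits. Among the compounds with values here, its parent compound 1 `CCc1ccccc1OS(=O)(=O)c1ccc(N2CCN(C)C2=O)cc1` gives 2300 nM in this assay, and the step of an at least 21-fold higher number from compound 1 to compound 3 (1.33 log units; beyond the scatter) therefore shows only that the propyl analogue sits beyond the reach of the measurement. Compound 2 `COc1cc(OS(=O)(=O)c2ccc(N3CCN(C)C3=O)cc2)cc(OC)c1OC` gives 54 nM in this assay; compounds 1 and 2 differ in the aryl ester part, and the two values show the methoxy-bearing aryl on the methyl core at the stronger end.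

Compound 4 `CCCN1CCN(c2ccc(S(=O)(=O)Oc3ccc(OC)cc3)cc2)C1=O` differs from compound 3 by 4-methoxyphenyl in place of 2-ethylphenyl on an oxygen. Within the data shown here, no measured step covers this change on the propyl core; the only measured step, from compound 1 to compound 3, concerns the ring nitrogen substituent and does not bear on the aryl ester. The values of compounds 1 and 2 give some grounds to expect a lower number in this assay, but compound 3 starts from a limit, so the size is uncertain. Compound 4 is expected to show an at least 2.5-fold lower number from compound 3 to compound 4 (0.39 log units; beyond the scatter), giving an estimated 20000 nM in this assay, within 3000 nM to 100000 nM, with a sizeable chance that again only a limit is reported.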

Compound 4, half-maximal inhibitory concentration: 23000 nM
For compound 4 the middle estimate is 1.2-fold (0.06 log units) below the measured one; low and high end bracket the measured number.
By their numbers in this assay, from the lowest: compound 2; then compound 1; then compound 4. At a limit, above all of these: compound 3.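

On the propyl core the aryl group on the sulfonate oxygen still matters: in this assay the change to 4-methoxyphenyl gives an at least 2.1-fold lower number from compound 3 to compound 4 (0.33 log units; beyond the scatter) and lies beyond the scatter. Compound 4 (23000 nM) thus gives this core a true number, so the loss seen with the propyl group need not put every aryl ester out of range. Compound 3 is held only by a limit, so the printed step is a lower bound and its full size stays unread: the limit of > 50000 nM in this assay, at which 1 of the 4 values shown sits.

The ethyl and methoxy groups change together with their places on the ring, and the compounds shown do not separate these two changes. Also open, on these data alone, is how a butyl chain, or a chain ending in an amine, on the ring nitrogen would fare with the 4-methoxyphenyl ester.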